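Moving a phenol hydroxyl on a trihydroxyphenylpyridine

This account rests on a few compounds, and the source may have more. Where it says the series, first, only, none or still open, it means among the compounds named here.

Measured so far:
compound 1, `Oc1cccc(-c2cc(-c3ccccc3O)cc(-c3ccccc3O)n2)c1`, 730 nM
compound 2, `Oc1ccc(-c2cc(-c3ccccc3O)nc(-c3ccccc3O)c2)cc1`, > 50000 nM

Of the compounds shown here, two have been tested in an ADME assay on HEK293 cells (Homo sapiens) for cytotoxicity, read by CCK-8 assay, with a stated time of 4 days; a lower number here means a stronger inhibitor, a higher number a weaker inhibitor. Compound 1, `Oc1cccc(-c2cc(-c3ccccc3O)cc(-c3ccccc3O)n2)c1`, gives 730 nM in this assay. Compound 2, `Oc1ccc(-c2cc(-c3ccccc3O)nc(-c3ccccc3O)c2)cc1`, reaches only the limit of this assay, > 50000 nM, so no number is known for it; the account notes that (the limit of > 50000 nM in this assay, at which 1 of the 2 values shown sits), and compound 2 is the one that sits there.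

The step to compound 3, `Oc1ccc(-c2cc(-c3cccc(O)c3)nc(-c3ccccc3O)c2)cc1`, keeps every atom and joins them differently: 3-hydroxyphenyl in place of 2-hydroxyphenyl on an aromatic carbon next to the ring nitrogen, meta to a 2-hydroxyphenyl group and meta to a 4-hydroxyphenyl group. Among the measured compounds shown here, no measured pair shows what such a shift does in this assay, and compound 2 itself offers only a limit, so the size of the step can only be guessed. The expected step from compound 2 to compound 3 is an at least 1.6-fold lower number from compound 2 to compound 3 (0.22 log units; that floor lies within the scatter), a small gain that may not clear the scatter. Compound 3 is accordingly estimated at 30000 nM, with a range from 5000 nM to 100000 nM.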

Compound 3, half-maximal inhibitory concentration: 7420 nM
Compound 3: the middle estimate sits 4.0-fold (0.61 log units) above what was measured; the measured number falls inside the stated range.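

In this assay, the hydroxyl on the group at the aromatic carbon next to the ring nitrogen is now seen to matter, since 3-hydroxyphenyl in place of 2-hydroxyphenyl there gives a clear change (an at least 6.7-fold lower number from compound 2 to compound 3 (0.82 log units; beyond the scatter)) with the atom count untouched. Compound 2 stands at a limit of the assay, so this step is a floor and not a full size: the limit of > 50000 nM in this assay, at which 1 of the 3 values shown sits. The second comparison (a 10-fold higher number from compound 1 to compound 3 (1.01 log units; beyond the scatter)) places compound 3 between the other two, so shifting a single hydroxyl among these aryl groups moves the number in either direction across these three compounds.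

From the compounds shown here alone, what a methoxy group or an amine in place of the moved hydroxyl would do remains open, and so does whether the hydroxyl is needed on that ring at all. The true number for compound 2 is also unknown, which leaves the upper size of the first step undefined.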